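A few compounds are considered here, and "the series" means these few. Any claim that something is new, unique, unknown or untested is made for them only; others in the source may bear on it.

Compound 1 `CC1=CC[C@H](C(C)C)c2cc(C)c(OC(=O)c3cccc(Cl)c3)cc21` gives 0.9% in a functional assay on U-251 cells (Homo sapiens) for antiproliferative activity, read by sulforhodamine B assay, with a stated time of 48 h, tested at 50 uM; a higher number here means more inhibition at the concentration tested (going by the name of the read-out), a lower number less inhibition.
Compound 2 `CC1=CC[C@H](C(C)C)c2cc(C)c(OC(=O)c3cccc(C)c3)cc21` gives 16.8% in this assay.
Compound 3 `CC1=CC[C@H](C(C)C)c2cc(C)c(OC(=O)c3cccc([N+](=O)[O-])c3)cc21` gives 44% in this assay.

Compound 3 stands highest of the three numbers. Its nearest neighbour is compound 2, separated by a number 27.2 percentage points higher from compound 2 to compound 3 (beyond the scatter), and the furthest is compound 1, separated by a number 43.1 percentage points higher from compound 1 to compound 3 (beyond the scatter); both gaps lie beyond the scatter.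

Compound 4 `COc1ccc(C(=O)Oc2cc3c(cc2C)[C@@H](C(C)C)CC=C3C)cc1` differs from compound 3 by 4-methoxyphenyl in place of 3-nitrophenyl on a carbonyl carbon. Going by the values given here, none of the measured steps involves a methoxy group or a 4-substituted phenyl ring; all three exchange one substituent of the phenyl ring for another: a number 15.9 percentage points higher from compound 1 to compound 2 (beyond the scatter), a number 43.1 percentage points higher from compound 1 to compound 3 (beyond the scatter) and a number 27.2 percentage points higher from compound 2 to compound 3 (beyond the scatter). Among the compounds with values here, they show only that the nitro group goes with the highest number and that each other substituent tested gave a lower one. On that basis a fall in this assay is expected for compound 4, probably beyond the scatter, estimated as a number 29 percentage points lower from compound 3 to compound 4 (beyond the scatter). Compound 4 is therefore expected near 15%, within 0% to 40%.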

Compound 4, a percentage reported as inhibition, at one concentration (the size of the read-out at that concentration, not a potency): 37%
For compound 4 the middle estimate is 22 percentage points below the measured one; the measured number falls inside the stated range.
By their numbers in this assay, from the lowest: compound 1; then compound 2; then compounds 4 and 3 (each within the scatter of the next).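

On a carbonyl carbon, 4-methoxyphenyl in place of 3-nitrophenyl gives a number 7 percentage points lower from compound 3 to compound 4 (within the scatter) in this assay, so the nitro group is not the only substituent tied to the top of this short series, and compounds 3 and 4 cannot be placed in order. Going by these compounds alone, the 4-methoxyphenyl ester also stands clear of the two lower compounds, with a number 20.2 percentage points higher from compound 2 to compound 4 (beyond the scatter) and a number 36.1 percentage points higher from compound 1 to compound 4 (beyond the scatter), and it is the first 4-substituted phenyl ring to be read against these 3-substituted rings. No available evidence bears on why these numbers differ.

The step from compound 3 to compound 4 changes both the group and where it sits on the phenyl ring, and the compounds shown do not separate these two changes. From the compounds shown here alone, how an amine or a carboxylic acid on that ring would read remains open.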